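This account rests on a few compounds, and the source may have more. Where it says the series, first, only, none or still open, it means among the compounds named here.

Compound 1 `CCCc1cc(=O)n([C@@H]2O[C@H](COP(=O)(O)OP(=O)(O)OP(=O)(O)O)[C@@H](O)[C@H]2O)c(=O)[nH]1` in an in vitro functional assay on 1321-N1 cells for agonist activity at P2Y purinoceptor 4 (Homo sapiens) (on this read-out higher numbers stand for an effect only at larger amounts of compound and lower numbers for an effect already at smaller amounts), gives > 100000 nM, which is a limit of the assay and not a number. Compound 3 `CCCc1cc(=O)n([C@@H]2O[C@H](COP(=O)(O)OP(=O)(O)O)[C@@H](O)[C@H]2O)c(=O)[nH]1` in this assay gives > 100000 nM, again a limit. Compound 2 `Cn1c(=O)ccn([C@@H]2O[C@H](COP(=O)(O)OP(=O)(O)O)[C@@H](O)[C@H]2O)c1=O` in this assay gives > 100000 nM, also a limit.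

Compound 1 and compound 3 differ in one place: a hydrogen atom in place of a group of 4 heavy atoms (3 oxygen, 1 phosphorus; no ring), on an oxygen. The step that the two limits leave unreadable from compound 1 to compound 3 cannot be read, since both values are limits. The core of compound 2 is different from that of compound 1, and the difference between the two cores is not broken down here. Compound 4 `Cn1c(=O)ccn([C@@H]2O[C@H](COP(=O)(O)O)[C@@H](O)[C@H]2O)c1=O` has not yet been measured; it differs from compound 2 by a hydrogen atom in place of a group of 4 heavy atoms (3 oxygen, 1 phosphorus; no ring), on an oxygen, the same change as that from compound 1 to compound 3, at a place described in the same words.

Among the compounds with values here, every value so far sits at the limit of > 100000 nM in this assay, at which 3 of the 3 values shown sit. Nothing within these data shows a change that a smaller phosphate chain makes. The expectation for compound 4 is therefore a step of a number no higher from compound 2 to compound 4 (the limit leaves the size open) of no readable size, giving an estimated value of 100000 nM in this assay, between 50000 nM and 1000000 nM, most likely reported only as a limit.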

Compound 4, half-maximal effective concentration: > 100000 nM
Compound 4 was reported as a limit; the forecaster's own chance of this, stated with the estimate: 90%; the middle value lies on the limit itself.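

Compound 2 and compound 4 both stand at a limit of the assay and not at a number, so the step between them cannot be read. The same is true of the whole set: the limit of > 100000 nM in this assay, at which 4 of the 4 values shown sit.

The compounds shown leave open whether the length of the phosphate chain matters at all in this assay.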